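Replacing a carbonyl-linked aryl by an arylamino in compound 4

This account rests on a few compounds, and the source may have more. Where it says the series, first, only, none or still open, it means among the compounds named here.

Compound 1: `Cc1cc(NNC(=O)Nc2cc(Cl)nc(Cl)c2)ncc1-c1cnn(C)c1` — 3.4 nM
Compound 2: `Cc1cc(NNC(=O)Nc2cc(Cl)nc(Cl)c2)ncc1-c1cn(C)nc1C` — 0.8 nM
Compound 3: `Cc1cc(CNC(=O)c2cc(Cl)nc(Cl)c2)ncc1-c1cn(C)nc1C` — > 100 nM
Compound 4: `Cc1cc(CNC(=O)Nc2cc(Cl)nc(Cl)c2)ncc1-c1cn(C)nc1C` — to be measured

In a functional assay on CHO cells for antagonist activity at sphingosine 1-phosphate receptor 2 (Homo sapiens), read by scintillation counting and GTPgammaS binding, with a stated time of 4 h, in the presence of a further agent that is not named here (a higher number here means a weaker inhibitor, a lower number a stronger inhibitor), compound 1 gives 3.4 nM. Among the measured compounds shown here, compound 2 gives 0.8 nM in this assay, and the change a 4.3-fold lower number from compound 1 to compound 2 (0.63 log units; beyond the scatter) is the only measured step within this small set. For compound 3 this assay reports only a limit, > 100 nM; the line the limit of > 100 nM in this assay, at which 1 of the 3 values shown sits, marks where that limit sits, so compound 3 stands apart from compounds 1 and 2 with no number of its own.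

The step to compound 4 is (2,6-dichloropyridin-4-yl)amino in place of 2,6-dichloropyridin-4-yl on a carbonyl carbon. Compound 4 thereby carries the (2,6-dichloropyridin-4-yl)amino group on the carbonyl carbon as compounds 1 and 2 do, while keeping the rest of compound 3. For the measured compounds named here, no measured step addresses this exact change; the step from compound 1 to compound 2 concerns a methyl and does not bear on it. The expectation therefore rests on compound 3 sitting at its limit and compounds 1 and 2 sitting far lower.

Compound 4 is expected to give 20 nM in this assay, within 3 nM to 150 nM. This estimate means a step of an at least 5.0-fold lower number from compound 3 to compound 4 (0.69 log units; beyond the scatter), expected to be a lower number, though it may still come back only as a limit.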

Compound 4, half-maximal inhibitory concentration: 0.77 nM
The estimate for compound 4 lay 26-fold (1.41 log units) above the measured number; the measured number lies below the stated range.
By their numbers in this assay, from the lowest: compounds 4 and 2 (each within the scatter of the next); then compound 1. At a limit, above all of these: compound 3.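

The earlier compounds shown here held no measured step at this carbonyl carbon, and in this assay the change from 2,6-dichloropyridin-4-yl to (2,6-dichloropyridin-4-yl)amino now gives an at least 120-fold lower number from compound 3 to compound 4 (2.11 log units; beyond the scatter), so this one exchange, which adds a nitrogen and a hydrogen-bond donor, separates a compound with a measured number from one without. The size of that step is itself open-ended, since compound 3 has only a limit and not a number: the limit of > 100 nM in this assay, at which 1 of the 4 values shown sits. Compound 2 gives 0.8 nM and compound 4 gives 0.77 nM, values within the scatter of each other, so a compound with the (2,6-dichloropyridin-4-yl)amino group and a different link on the other side of the carbonyl stands in the same range.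

The compounds shown leave open whether the step belongs to the nitrogen itself or to its hydrogen, which a methylamino link or an ether oxygen in the same place would separate. They also leave open whether the step would hold with the two chlorine atoms replaced by methyl groups.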